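Methyl ester in place of methoxy: cytotoxicity outlook

A few compounds are considered here, and "the series" means these few. Any claim that something is new, unique, unknown or untested is made for them only; others in the source may bear on it.

Among the measured compounds shown here, compound 2 `COc1ccc(-c2nn(-c3ccc(F)cc3F)cc2CNCCN2CCN(C)CC2)cc1` is one of two compounds measured in an ADME assay on Huh-7 cells (Homo sapiens) for cytotoxicity; on this read-out lower numbers stand for higher toxicity in this test and higher numbers for lower toxicity in this test. In that test compound 2 gives > 20000 nM, which is a limit of the assay rather than a number. Compound 1 `CN1CCN(CCNCc2cn(-c3ccc(F)cc3F)nc2Cc2ccccc2)CC1` shares the core and carries a benzyl group where compound 2 carries a 4-methoxyphenyl. In this assay compound 1 gives > 20000 nM, again a limit. The step that the two limits leave unreadable from compound 1 to compound 2 therefore cannot be read, and the only firm point is the limit of > 20000 nM in this assay, at which 2 of the 2 values shown sit. Compound 3 `COC(=O)c1ccc(-c2nn(-c3ccc(F)cc3F)cc2CNCCN2CCN(C)CC2)cc1` differs from compound 2 by methoxycarbonyl in place of methoxy on an aromatic carbon. No readable measured step bears on this change; the two values shown are both limits. The step that the limit leaves unreadable from compound 2 to compound 3 is therefore expected to be none beyond the scatter. Compound 3 is estimated at 25000 nM, with a range from 10000 nM to 60000 nM, most likely reported again as a limit.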

Compound 3, half-maximal cytotoxic concentration: > 20000 nM
Compound 3 ended at the assay's limit (the forecaster's own chance of this, stated with the estimate: 80%); the middle value lies beyond the limit too.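

Compound 3 again reaches a limit of the assay, so no step between compound 1, compound 2 and compound 3 can be read in this assay: the limit of > 20000 nM in this assay, at which 3 of the 3 values shown sit.

The compounds shown leave open whether any of these changes to the shared core alters cytotoxicity at all, and by how much.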